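The compounds below may be only part of what the source reports. "The series", "measured", "known", "first", "only" and "open" are said of these compounds alone.

Compound 1 `C=C(Br)C(=O)Nc1ccc(/C=C/C(=O)c2ccc(Cl)cc2)cc1`: 950 nM
Compound 2 `C=C(Br)C(=O)Nc1ccc(/C=C/C(=O)c2ccc(Cl)c(Cl)c2)cc1`: 1700 nM

Going by the values given here, in an ADME assay on CCRF-CEM cells (Homo sapiens) for antiproliferative activity, with a stated time of 48 h (on this read-out higher numbers stand for weaker inhibition and lower numbers for stronger inhibition), compound 1 gives 950 nM, and compound 2, the only other measured compound, lies within the scatter of it. Compound 3 `C=C(Br)C(=O)Nc1ccc(/C=C/C(=O)c2ccc(C)cc2)cc1` has methyl in place of chloro on an aromatic carbon, para to a large group: methyl in place of chloro on an aromatic carbon. Among the compounds with values here, only one measured step bears on this, a 1.8-fold higher number from compound 1 to compound 2 (0.25 log units; within the scatter), and it adds chloro in place of hydrogen rather than testing methyl. With so little evidence, no step beyond the scatter is expected in this assay. The expected change is a 1.1-fold higher number from compound 1 to compound 3 (0.02 log units; within the scatter). For compound 3 the estimate is 1000 nM, with an expected range of 450 nM to 2200 nM.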

Compound 3, half-maximal inhibitory concentration: 1800 nM
The estimate for compound 3 lay 1.8-fold (0.26 log units) below the measured number, and the stated range covers the measured number.
By their numbers in this assay, from the lowest: compounds 1, 2 and 3 (each within the scatter of the next).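

Methyl in place of chloro on this aromatic carbon, para to a large group, gives a 1.9-fold higher number from compound 1 to compound 3 (0.28 log units; within the scatter) in this assay. Putting 4-methylphenyl in place of 3,4-dichlorophenyl gives a 1.1-fold higher number from compound 2 to compound 3 (0.02 log units; within the scatter), so this assay does not yet separate these three aryl groups. No measurement is available that would explain this result. As far as these compounds go, whether an amine or a carboxylic acid at this position would move the number beyond the scatter remains open. So does whether a methoxy group there would do so.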